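This account rests on a few compounds, and the source may have more. Where it says the series, first, only, none or still open, it means among the compounds named here.

In a functional assay on HepG2 cells (Homo sapiens) for antiproliferative activity, read by MTT assay, with a stated time of 48 h (a higher number here means a weaker inhibitor, a lower number a stronger inhibitor), compound 1 (`COc1ccc(-c2ccc3c(c2)C(=O)C(=O)N3Cc2cc(C)cc(C)c2)cc1`) gives 410 nM and compound 2 (`COc1ccc(-c2ccc3c(c2)C(=O)C(=O)N3Cc2ccc(OC)c(OC)c2)cc1`) gives 1350 nM. Compound 3 (`COc1ccc(CN2C(=O)C(=O)c3cc(-c4cc(OC)cc(OC)c4)ccc32)cc1`) gives 1200 nM, within the scatter of compound 2 and a higher number than compound 1. Compound 4 (`COc1ccc(CN2C(=O)C(=O)c3cc(-c4ccc(OC(C)C)cc4)ccc32)cc1`) keeps the rest of compound 3 but has 4-isopropoxyphenyl in place of 3,5-dimethoxyphenyl on an aromatic carbon. For the measured compounds named here, the only measured step, a 3.3-fold higher number from compound 1 to compound 2 (0.52 log units; beyond the scatter), lies at a different place, so it gives no direction for this change and serves only as a modest guide to size. The expected step is a 1.2-fold lower number from compound 3 to compound 4 (0.08 log units; within the scatter), which is estimated to stay within the scatter. The estimate for compound 4 is 1000 nM, with an expected range of 350 nM to 2800 nM.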

Compound 4, half-maximal inhibitory concentration: > 10000 nM
Compound 4 ended at the assay's limit (the forecaster's own chance of this, stated with the estimate: 3%); middle value at least 10-fold (1.00 log units) from the limit.
By their numbers in this assay, from the lowest: compound 1; then compounds 3 and 2 (each within the scatter of the next). At a limit, above all of these: compound 4.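

In this assay, 4-isopropoxyphenyl in place of 3,5-dimethoxyphenyl on an aromatic carbon brings an at least 8.3-fold higher number from compound 3 to compound 4 (0.92 log units; beyond the scatter), so the group at this position, which the earlier step left untouched, can decide the result. The value of compound 4, > 10000 nM, is a limit of the assay and not a number. The two groups match in heavy-atom count, so the step does not follow that count. As far as these compounds go, whether a 4-ethoxyphenyl or 4-aminophenyl group here would stay near compound 3 remains open. So does whether the step would carry over to the 3,5-dimethylphenyl series of compound 1.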